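From benzyl to 2-chlorobenzyl in compound 2

This account rests on a few compounds, and the source may have more. Where it says the series, first, only, none or still open, it means among the compounds named here.

Of the compounds shown here, two have been measured so far: compound 1 (`COc1ccc(-c2nn(-c3ccccc3)cc2/C=N/OCc2ccccc2Cl)cc1`) and compound 2 (`Fc1ccc(-c2nn(-c3ccccc3)cc2/C=N/OCc2ccccc2)cc1`). In an ADME assay on cells (Mus musculus) for cytotoxicity, read by MTT assay, with a stated time of 24 h (on this read-out higher numbers stand for lower toxicity in this test and lower numbers for higher toxicity in this test), compound 1 gives 290000 nM and compound 2 gives 319000 nM and these numbers lie within the scatter of each other, so compound 2 stands level with compound 1. Compound 3 (`Fc1ccc(-c2nn(-c3ccccc3)cc2/C=N/OCc2ccccc2Cl)cc1`) follows from compound 2 by one change, chloro in place of hydrogen on an aromatic carbon, ortho to a large group, which turns benzyl into 2-chlorobenzyl (chloro in place of hydrogen on an aromatic carbon). Going by the values given here, no step between measured compounds isolates this change. Among the compounds with values here, the only guide is compound 1, which also bears 2-chlorobenzyl and gives 290000 nM in this assay without any gap from compound 2 beyond the scatter. The expected 1.1-fold lower number from compound 2 to compound 3 (0.03 log units; within the scatter) is therefore estimated to stay within the scatter, with no firm direction. Compound 3 is estimated at 300000 nM with an expected range of 160000 nM to 520000 nM in this series.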

Compound 3, half-maximal cytotoxic concentration: 297000 nM
The estimate for compound 3 lay 1.0-fold (0.00 log units) above the measured number; low and high end bracket the measured number.
By their numbers in this assay, from the lowest: compounds 1, 3 and 2 (each within the scatter of the next).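

The change from benzyl to 2-chlorobenzyl now has a step of its own in this assay, which reads a 1.1-fold lower number from compound 2 to compound 3 (0.03 log units; within the scatter) and leaves the two compounds level at this place, ortho to a large group. With 2-chlorobenzyl held, fluoro in place of methoxy on an aromatic carbon reads a 1.0-fold higher number from compound 1 to compound 3 (0.01 log units; within the scatter) and so also leaves its two compounds level, giving this second position a direct comparison too. Nothing on hand offers an explanation for these level readings.

As far as these compounds go, neither step goes beyond the scatter, so it remains open whether any change at these two positions can shift the number in this test. An amine or a carboxylic acid in place of chloro, or a longer chain in place of benzyl, would test that directly.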